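Adding a Nitrophenyl to the Hydrazone of Compound 2

This account rests on a few compounds, and the source may have more. Where it says the series, first, only, none or still open, it means among the compounds named here.

Compound 2 `N/N=C\c1cc(=O)oc2cc(OCc3ccccc3)cc(OCc3ccccc3)c12` gives the highest number of the three measured compounds in a functional assay, read by spectrophotometry, with a stated time of 3 min (on this read-out lower numbers stand for stronger inhibition and higher numbers for weaker inhibition), with 363000 nM. Compound 1 `O=c1cc(/C=N\c2ccccc2O)c2c(OCc3ccccc3)cc(OCc3ccccc3)cc2o1` gives 7760 nM in this assay, and compound 3 `N/N=C\c1cc(=O)oc2cc(OCc3ccccc3)ccc12` gives 9740 nM. The step of a 47-fold higher number from compound 1 to compound 2 (1.67 log units; beyond the scatter) and the step of a 37-fold lower number from compound 2 to compound 3 (1.57 log units; beyond the scatter) both set compound 2 apart from its neighbours by margins well beyond the scatter.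

Compound 4 `O=c1cc(/C=N\Nc2ccc([N+](=O)[O-])cc2)c2c(OCc3ccccc3)cc(OCc3ccccc3)cc2o1` differs from compound 2 by 4-nitrophenyl in place of hydrogen on an amine nitrogen. Going by the values given here, no measured step reproduces this change exactly. The closest is a 47-fold higher number from compound 1 to compound 2 (1.67 log units; beyond the scatter), in which an aromatic ring attached to the double-bonded nitrogen was exchanged for an amino group and the number rose sharply; compound 4 brings an aromatic ring back, though now on the amine nitrogen and carrying a nitro group instead of a hydroxyl. The step of a 37-fold lower number from compound 2 to compound 3 (1.57 log units; beyond the scatter) shows that compound 2 is far from any floor in this assay and that large movements are possible from it. On this basis a large fall in number is expected for compound 4, of roughly a 36-fold lower number from compound 2 to compound 4 (1.56 log units; beyond the scatter). Compound 4 is therefore estimated at 10000 nM, with a range from 2000 nM to 80000 nM.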

Compound 4, half-maximal inhibitory concentration: 15500 nM
Beside the measured number, compound 4's estimate is 1.6-fold (0.19 log units) below it, and the stated range covers the measured number.
By their numbers in this assay, from the lowest: compounds 1, 3 and 4 (each within the scatter of the next); then compound 2.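

In this assay, going by these compounds alone, the amine nitrogen proves to be a position where substitution counts: 4-nitrophenyl in place of hydrogen there gives a 23-fold lower number from compound 2 to compound 4 (1.37 log units; beyond the scatter) and is the first measured change made on that nitrogen itself. The earlier step, a 47-fold higher number from compound 1 to compound 2 (1.67 log units; beyond the scatter) when amino replaced 2-hydroxyphenyl on the double-bonded nitrogen, is now joined by a second comparison at that place, where (4-nitrophenyl)amino in place of 2-hydroxyphenyl reads as a 2.0-fold higher number from compound 1 to compound 4 (0.30 log units; within the scatter) and so leaves these two aromatic groups indistinguishable in this assay. Both aromatic groups thus stand apart from the amino group of compound 2, although compound 3 goes against any rule that this amino group alone brings a high number, since compound 3 keeps it and gives 9740 nM in this assay.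

From the compounds shown here alone, it remains open whether an unsubstituted phenyl, or a phenyl carrying an amine or a carboxylic acid where compound 4 has its nitro group, would give a similar fall. Going by these compounds, it is also open whether a methyl on the amine nitrogen, with no ring at all, would move the number, and whether 4-nitrophenyl would act in the same way on the core of compound 3. No measurement shown here gives a reason for these steps.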